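Trifluoromethyl for methoxy on a potent cytotoxic compound

A few compounds are considered here, and "the series" means these few. Any claim that something is new, unique, unknown or untested is made for them only; others in the source may bear on it.

Compound 1 `COc1ccc(CN2C(=O)C(=O)c3cc(/C=C/C(=O)OCCO)ccc32)cc1`: 860 nM
Compound 2 `COC(=O)/C=C/c1ccc2c(c1)C(=O)C(=O)N2Cc1ccc(OC)cc1`: 30 nM

In a functional assay on HepG2 cells (Homo sapiens) for cytotoxicity, read by MTT assay, with a stated time of 48 h (a lower number here means a stronger inhibitor, a higher number a weaker inhibitor), compound 2 holds the lower of the two numbers. Compound 3 `COC(=O)/C=C/c1ccc2c(c1)C(=O)C(=O)N2Cc1ccc(C(F)(F)F)cc1` differs from compound 2 in one place: trifluoromethyl in place of methoxy on an aromatic carbon. Trifluoromethyl replaces methoxy on an aromatic carbon. For the measured compounds named here, the only measured step, a 29-fold lower number from compound 1 to compound 2 (1.46 log units; beyond the scatter), is large, but it concerns a saturated chain carbon elsewhere in the molecule. Going by the values given here, no measurement yet covers this aromatic carbon, so no clear direction can be drawn, and a change within the scatter is the cautious expectation. The expected change is a 1.5-fold higher number from compound 2 to compound 3 (0.18 log units; within the scatter). The estimate for compound 3 is 45 nM, with an expected range of 12 nM to 170 nM.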

Compound 3, half-maximal inhibitory concentration: 70 nM
For compound 3 the middle estimate is 1.6-fold (0.19 log units) below the measured one; measured number inside the range.
By their numbers in this assay, from the lowest: compound 2; then compound 3; then compound 1.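

For the compounds shown here, this is the first reading at this aromatic carbon: in this assay, trifluoromethyl in place of methoxy gives a 2.3-fold higher number from compound 2 to compound 3 (0.37 log units; beyond the scatter) and so shows that the position responds to this change, though modestly. That step is much smaller than the one on the saturated chain carbon, a 29-fold lower number from compound 1 to compound 2 (1.46 log units; beyond the scatter). Nothing at hand gives a reason for it. Going by these compounds, whether an amine or a chlorine atom on this aromatic carbon would move the number further in either direction remains open. On these data alone, it is also open whether this change would give a similar step on the core of compound 1.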